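The compounds below may be only part of what the source reports. "The series", "measured", "known", "first", "only" and "open" are said of these compounds alone.

In a functional assay on CCRF-CEM cells (Homo sapiens) for inhibition, read by sulforhodamine B assay, with a stated time of 48 h (a higher number here means a weaker inhibitor of growth, a lower number a stronger inhibitor of growth), compound 1 `COc1cc(C)cc(-c2c(-c3ccnc(-c4ccc(C(C)=O)cc4)c3)cnn2CC#N)c1` gives 2970 nM. For the measured compounds named here, the only other compound measured, compound 2 `Cc1cc(O)cc(-c2nn(CC#N)cc2-c2ccnc(-c3ccc(N(C)C)cc3)c2)c1`, gives 3590 nM in this assay. The two numbers lie within the usual scatter of each other, so compound 1 is not set apart from compound 2 on this evidence; the two compounds also differ from one another in two places, so no single change can be read from that pair.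

Compound 3 `COc1cc(C)cc(-c2c(-c3ccnc(-c4ccc(N(C)C)cc4)c3)cnn2CC#N)c1` has not yet been measured. It differs from compound 1 in one place: dimethylamino in place of acetyl on an aromatic carbon. The same exchange is present in compound 2, where it is joined by a second change, and compound 2 gives a number close to that of compound 1.

Going by the values given here, no step between measured compounds is available for this exchange alone. The expectation for compound 3 therefore rests on the closeness of compound 2 to compound 1, and a step in this assay of a 1.1-fold higher number from compound 1 to compound 3 (0.03 log units; within the scatter) is expected, no larger than the scatter in either direction. For compound 3 the estimate in this assay is 3200 nM, within a range from 1500 nM to 7000 nM.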

Compound 3, concentration for 50% growth inhibition: 237 nM
Compound 3: middle estimate off by 14-fold (1.13 log units), on the high side, outside the stated range (below it).
By their numbers in this assay, from the lowest: compound 3; then compounds 1 and 2 (each within the scatter of the next).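

In this assay, for the compounds shown here, the exchange of acetyl for dimethylamino on an aromatic carbon para to a large group stands alone for the first time, and it gives a 13-fold lower number from compound 1 to compound 3 (1.10 log units; beyond the scatter). The earlier pair differed in two places and could not isolate this change, whereas this step shows that the number on the core of compound 1 depends strongly on the group at this position. The two groups match in heavy-atom count, hydrogen-bond donors and acceptors, and net charge, so these counts do not separate them, and nothing available explains the step.

Whether the gain is particular to dimethylamino remains open, as neither a primary amine, a morpholine ring, nor a methoxy group at this position appears among the compounds shown. It is also unknown whether the same exchange gives a step of similar size with a hydroxy group in place of the methoxy group on the other aromatic ring, on an otherwise unchanged core.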